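Amide to carbamoyl on a shared core, no toxicity expected

A few compounds are considered here, and "the series" means these few. Any claim that something is new, unique, unknown or untested is made for them only; others in the source may bear on it.

Compound 1 `COc1cc(-c2nn(-c3cccc(NC(=O)c4cccc(C(F)(F)F)c4)c3)cc2-c2ccncc2)ccc1Cl` gives only a limit in a functional assay on NCI-H460 cells (Homo sapiens) for inhibition, read by sulforhodamine B assay, with a stated time of 48 h (on this read-out lower numbers stand for higher toxicity in this test and higher numbers for lower toxicity in this test), reading > 50000 nM. Compound 2 `O=C(Nc1cccc(-n2cc(-c3ccncc3)c(-c3ccc(Cl)c(O)c3)n2)c1)Nc1ccc(Cl)c(C(F)(F)F)c1` likewise gives only a limit in this assay, namely > 32500 nM. Going by the values given here, compound 1 therefore stands at a limit, as does the one other value shown, and no toxicity has been measured for either. Compound 3 `COc1cc(-c2nn(-c3cccc(NC(=O)Nc4ccc(Cl)c(Cl)c4)c3)cc2-c2ccncc2)ccc1Cl` differs from compound 1 by (3,4-dichlorophenyl)amino in place of 3-(trifluoromethyl)phenyl on a carbonyl carbon, so that a (3,4-dichlorophenyl)carbamoyl group now sits where the (3-(trifluoromethyl)phenyl)carbonyl stood. Among the compounds with values here, no step between measured compounds is known. Compound 3 is expected to show a step that the limit leaves unreadable from compound 1 to compound 3, none beyond the scatter. Compound 3 is thus estimated at 60000 nM, within 20000 nM to 200000 nM.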

Compound 3, concentration lethal to 50% of the cells: > 50000 nM
Compound 3 ended at the assay's limit; the forecaster's own chance of this, stated with the estimate: 80%; the middle value is on the limit's open side.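

Going by these compounds alone, compound 1 and compound 3 each give only a limit in this assay, and no step between them can be read. The compounds shown leave open what lethal concentration, if any, each actually has in this assay.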